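This account rests on a few compounds, and the source may have more. Where it says the series, first, only, none or still open, it means among the compounds named here.

Measured compounds:
- compound 1, `COC(=O)N[C@@H](CSC)C(=O)N1CCC[C@H]1c1ncc(-c2ccc(-c3ccc(-c4cnc([C@@H]5CCCN5C(=O)[C@@H](NC(=O)OC)C(C)C)[nH]4)cc3)cc2)[nH]1`: in an ADME assay on Huh-7 cells (Homo sapiens) for cytotoxicity (a lower number here means that less compound is tolerated, a higher number that more compound is tolerated), compound 1 gives "not determined" (no result reported).
- compound 2, `COC(=O)N[C@@H](CSC(C)(C)C)C(=O)N1CCC[C@H]1c1ncc(-c2ccc(-c3ccc(-c4cnc([C@@H]5CCCN5C(=O)[C@@H](NC(=O)OC)C(C)C)[nH]4)cc3)cc2)[nH]1`: in this assay compound 2 gives > 330000 nM, which is a limit of the assay and not a number.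

Compound 2 thus stands at the limit described by the limit of > 330000 nM in this assay, at which 1 of the 2 values shown sits, and compound 1 adds no number to place it against. Within the data shown here, no step between measured compounds is available in this assay, so the series gives no measured direction for a change at the sulfur.

Compound 3, `COC(=O)N[C@@H](CSCc1ccccc1)C(=O)N1CCC[C@H]1c1ncc(-c2ccc(-c3ccc(-c4cnc([C@@H]5CCCN5C(=O)[C@@H](NC(=O)OC)C(C)C)[nH]4)cc3)cc2)[nH]1`, differs from compound 2 by benzyl in place of tert-butyl on a sulfur. With only a limit to start from, the step expected in this assay is none beyond the scatter, and a further limit remains the likeliest outcome. Compound 3 is therefore estimated at 300000 nM, within 80000 nM to 600000 nM, the expected step being an at least 1.1-fold lower number from compound 2 to compound 3 (0.04 log units; that floor lies within the scatter).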

Compound 3, half-maximal cytotoxic concentration: > 330000 nM
Compound 3 was reported as a limit (the forecaster's own chance of this, stated with the estimate: 60%); at least 1.1-fold (0.04 log units) between middle value and limit.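

In this assay, no step can be read from compound 2 to compound 3, because both results are limits of the assay and not numbers: the limit of > 330000 nM in this assay, at which 2 of the 3 values shown sit.

The compounds shown leave open whether benzyl in place of tert-butyl on a sulfur changes this read-out at all.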